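A few compounds are considered here, and "the series" means these few. Any claim that something is new, unique, unknown or untested is made for them only; others in the source may bear on it.

Compound 1 `COc1ccc(-c2cn(C(=O)Nc3cc(OC)c(OC)c(OC)c3)c(=O)n2-c2cc(OC)c(OC)c(OC)c2)cc1OC` reaches only a limit of > 50000 nM in a functional assay on ECa-109 cells (Homo sapiens) for cytotoxicity, read by MTT assay, with a stated time of 48 h (a lower number here means a stronger inhibitor, a higher number a weaker inhibitor), and no number. Among the compounds with values here, compound 2 `COc1cc(-n2c(-c3ccc(Br)cc3)cn(C(C)=O)c2=O)cc(OC)c1OC` gives 3800 nM in this assay as the only true number so far. Compound 3 `COc1cc(-n2c(-c3ccc([N+](=O)[O-])cc3)cn(C(C)=O)c2=O)cc(OC)c1OC` carries nitro in place of bromo on an aromatic carbon para to a large group, the change from 4-bromophenyl to 4-nitrophenyl. Within the data shown here, no measured step bears on this change, so no shift beyond the scatter is expected in this assay for it. The estimated step of a 1.1-fold higher number from compound 2 to compound 3 (0.02 log units; within the scatter) carries no firm direction. Compound 3 is expected at 4000 nM with an estimated range from 1000 nM to 18000 nM in this measurement.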

Compound 3, half-maximal inhibitory concentration: > 50000 nM
Compound 3: only a limit was reported; the forecaster's own chance of this, stated with the estimate: 10%; middle value at least 12-fold (1.09 log units) from the limit.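

Within the data shown here, the change from 4-bromophenyl to 4-nitrophenyl is the first measured step at this position, and it is not silent: it gives an at least 13-fold higher number from compound 2 to compound 3 (1.11 log units; beyond the scatter) in this assay. Compound 3 gives > 50000 nM, which is a limit and not a number. Bromo thus remains the only group at this position with a true number, and the other values shown end at the same limit: the limit of > 50000 nM in this assay, at which 2 of the 3 values shown sit.

On these data alone, whether chloro, fluoro or an amine in place of bromo would give a true number stays open. One step at one position also shows no trend across groups.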